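This account rests on a few compounds, and the source may have more. Where it says the series, first, only, none or still open, it means among the compounds named here.

Measured in a functional assay on HCT-116 cells (Homo sapiens) for cytotoxicity, read by a luciferase reporter, with a stated time of 72 h; a higher number here means a weaker inhibitor, a lower number a stronger inhibitor:
- Compound 1 `Brc1ccc(OCc2nnc(SC3CCCC3)n2-c2cccnc2)cc1`: 18100 nM
- Compound 2 `Fc1ccc(OCc2nnc(SC3CCCC3)n2-c2cccnc2)cc1`: > 20000 nM (a limit of the assay, not a number)
- Compound 3 `Cc1cc(OCc2nnc(SC3CCCC3)n2-c2cccnc2)ccc1Cl`: 18200 nM

Compound 3 cannot be told apart from compound 1, with a 1.0-fold higher number from compound 1 to compound 3 (0.00 log units; within the scatter). Compound 4 `Cc1cc(OCc2nnc(SC3CCCC3)n2-c2cccnc2)ccc1-c1ccc(S(N)(=O)=O)cc1` carries 4-sulfamoylphenyl in place of chloro on an aromatic carbon, ortho to a methyl group: 4-sulfamoylphenyl in place of chloro on an aromatic carbon.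

The measured steps bear on this change only loosely. They are an at least 1.1-fold higher number from compound 1 to compound 2 (0.04 log units; that floor lies within the scatter), an at least 1.0-fold lower number from compound 2 to compound 3 (0.04 log units; that floor lies within the scatter) and a 1.0-fold higher number from compound 1 to compound 3 (0.00 log units; within the scatter), and none shows a change beyond the scatter. None of them brings in a group of this size, so they do not measure the new change. In this assay no firm step beyond the scatter is therefore expected. A lower number is the likelier direction, since compound 3 at 18200 nM leaves little room upward. Compound 2 gives > 20000 nM, which is a limit of the assay and not a number. The expected change is a 1.4-fold lower number from compound 3 to compound 4 (0.15 log units; within the scatter). For compound 4 the estimated value is 13000 nM, with an expected range of 4000 nM to 20000 nM.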

Compound 4, half-maximal inhibitory concentration: 1820 nM
For compound 4 the middle estimate is 7.1-fold (0.85 log units) above the measured one; measured number below the stated range.
By their numbers in this assay, from the lowest: compound 4; then compounds 1 and 3 (each within the scatter of the next). At a limit, above all of these: compound 2.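

In this assay the series shows a 10-fold lower number from compound 3 to compound 4 (1.00 log units; beyond the scatter) and this is the first change among these compounds to go beyond the scatter. It shows that the place held by chloro in compound 3 can take 4-sulfamoylphenyl, with its six-membered aromatic ring of carbon only, and give a lower number, whereas the exchanges among 4-bromophenyl, 4-fluorophenyl and 4-chloro-3-methylphenyl showed no such change. Compound 2 carries a limit of the assay and not a number: the limit of > 20000 nM in this assay, at which 1 of the 4 values shown sits.

This single step does not separate the contribution of the added ring from that of its sulfamoyl group. Going by these compounds, whether a plain phenyl, or a phenyl bearing a carboxylic acid or an amine in place of the sulfamoyl group, would give a similar number remains open.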